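This account rests on a few compounds, and the source may have more. Where it says the series, first, only, none or still open, it means among the compounds named here.

Measured compounds:
Compound 1 `Cn1ncc(Cl)c1-c1cc(C(=O)N[C@@H]2CN[C@H](CC(O)CO)C[C@H]2c2ccc(Cl)c(Cl)c2)oc1Cl`; in an assay for inhibition of RAC-alpha serine/threonine-protein kinase (Homo sapiens), read by HTRF, with a stated time of 1 h (a higher number here means a weaker inhibitor, a lower number a stronger inhibitor), compound 1 gives 3.79 nM.
Compound 2 `Cn1ncc(Cl)c1-c1cc(C(=O)N[C@@H]2CN[C@H](CCN3CCC(O)CC3)C[C@H]2c2ccc(Cl)c(Cl)c2)oc1Cl`; in this assay compound 2 gives 5.99 nM.

Compound 2 has the higher of these two numbers, yet it lies within the scatter of compound 1. Compound 3 `Cn1ncc(Cl)c1-c1cc(C(=O)N[C@@H]2CN[C@H](CCCO)C[C@H]2c2ccc(Cl)c(Cl)c2)oc1Cl` carries hydroxymethyl in place of 4-hydroxypiperidin-1-yl on a saturated chain carbon, two bonds along the chain from a saturated ring carbon. Among the compounds with values here, the one step that bears on this is a 1.6-fold higher number from compound 1 to compound 2 (0.20 log units; within the scatter), where the same ring replaced a 1,2-dihydroxyethyl group without moving the number beyond the scatter. Returning to a short hydroxyl chain is therefore expected to give no step beyond the scatter, a 1.2-fold lower number from compound 2 to compound 3 (0.08 log units; within the scatter). Compound 3 is estimated at 5 nM, with a range from 2 nM to 12 nM.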

Compound 3, half-maximal inhibitory concentration: 2.56 nM
Compound 3: the middle estimate sits 2.0-fold (0.29 log units) above what was measured; low and high end bracket the measured number.
By their numbers in this assay, from the lowest: compounds 3, 1 and 2 (each within the scatter of the next, the first and the last beyond it).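

Swapping the 4-hydroxypiperidin-1-yl ring for hydroxymethyl, on a saturated chain carbon two bonds along the chain from a saturated ring carbon, gives a 2.3-fold lower number from compound 2 to compound 3 (0.37 log units; beyond the scatter) in this assay, so the large ring is not required at this place. Hydrogen in place of hydroxy on the chain gives a 1.5-fold lower number from compound 1 to compound 3 (0.17 log units; within the scatter) and so shows that the second hydroxy can go without a change beyond the scatter. Nothing measured here explains either step. From the compounds shown here alone, whether a 3-aminopropyl chain, a carboxylic acid or a longer hydroxyl chain would serve equally well remains open.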